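The compounds below may be only part of what the source reports. "The series", "measured", "known", "first", "only" and "open" are said of these compounds alone.

Compound 3 `Cc1cc(=O)n(-c2ccc(Br)cc2F)nc1C(=O)Nc1ccc(Oc2ncnc3sccc23)cc1` stands lowest among the numbers seen in a functional assay on HepG2 cells (Homo sapiens) for cytotoxicity, read by MTT assay, with a stated time of 72 h; on this read-out higher numbers stand for weaker inhibition and lower numbers for stronger inhibition; compound 1 `Cc1cc(=O)n(-c2ccccc2OC(F)(F)F)nc1C(=O)Nc1ccc(Oc2ncnc3ccsc23)cc1`, which carries the other core, gives 25000 nM. Compound 2 `Cc1cc(=O)n(-c2ccccc2C(F)(F)F)nc1C(=O)Nc1ccc(Oc2ncnc3sccc23)cc1` gives only a limit of the assay, > 40000 nM. In this assay compound 3 gives 6300 nM. Compound 4 `Cc1cc(=O)n(-c2ccccc2OC(F)(F)F)nc1C(=O)Nc1ccc(Oc2ncnc3sccc23)cc1` differs from compound 3 by 2-(trifluoromethoxy)phenyl in place of 4-bromo-2-fluorophenyl on an aromatic nitrogen. Going by the values given here, the one measured step at this position, an at least 6.3-fold lower number from compound 2 to compound 3 (0.80 log units; beyond the scatter), runs the other way: it goes from an ortho-substituted phenyl to the 4-bromo-2-fluorophenyl, and its size is bounded only by the limit of > 40000 nM in this assay, at which 1 of the 3 values shown sits. Among the compounds with values here, compound 1 shows the same 2-(trifluoromethoxy)phenyl on a different core together with a higher number than compound 3, though no single step links those two. Taken together, a return to an ortho-substituted phenyl is expected to raise the number, and compound 4 is estimated at 25000 nM, between 8000 nM and 60000 nM, which means an expected step of a 4.0-fold higher number from compound 3 to compound 4 (0.60 log units; beyond the scatter).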

Compound 4, half-maximal inhibitory concentration: 14400 nM
Compound 4: middle estimate off by 1.7-fold (0.24 log units), on the high side; measured number inside the range.
By their numbers in this assay, from the lowest: compound 3; then compounds 4 and 1 (each within the scatter of the next). At a limit, above all of these: compound 2.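

In this assay, a 2.3-fold higher number from compound 3 to compound 4 (0.36 log units; beyond the scatter) shows that, on the shared core, 2-(trifluoromethoxy)phenyl on the aromatic nitrogen gives a measured rise over 4-bromo-2-fluorophenyl, although the gain seen earlier at this position was only bounded. Trifluoromethoxy in place of trifluoromethyl gives an at least 2.7-fold lower number from compound 2 to compound 4 (0.44 log units; beyond the scatter), so the two ortho-substituted phenyls also separate, with the size of that step bounded by the value of compound 2, which is a limit: the limit of > 40000 nM in this assay, at which 1 of the 4 values shown sits. The change of core with 2-(trifluoromethoxy)phenyl held fixed gives a 1.7-fold lower number from compound 1 to compound 4 (0.24 log units; within the scatter), so the two cores are not told apart on this read-out.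

The compounds shown leave open whether 4-bromo-2-fluorophenyl keeps its number on the core of compound 1, and whether the bromine or the fluorine accounts for it. They also leave open how the number responds to a phenyl carrying an amine or a carboxylic acid.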